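The compounds below may be only part of what the source reports. "The series", "measured", "known", "first", "only" and "open" are said of these compounds alone.

Series notes. Going by the values given here, compound 3 `Cc1cc(C)c(Oc2cc(Nc3ccc(C#N)cc3)ncc2C(=O)NCc2cn(Cc3cccc(Cl)c3)nn2)c(C)c1` stands highest of the three numbers so far in an ADME assay on MT4 cells (Homo sapiens) for cytotoxicity, read by MTT assay, with a stated time of 5 days; a lower number here means that less compound is tolerated, a higher number that more compound is tolerated: compound 3 gives 187000 nM. Compound 1 `Cc1cccc(Cn2cc(CNC(=O)c3cnc(Nc4ccc(C#N)cc4)cc3Oc3c(C)cc(C)cc3C)nn2)c1` is the nearest; in this assay compound 1 gives 114000 nM, and the step of a 1.6-fold higher number from compound 1 to compound 3 (0.21 log units; within the scatter) stays inside the scatter. Compound 2 `Cc1cc(C)c(Oc2cc(Nc3ccc(C#N)cc3)ncc2C(=O)NCc2cn(CC(N)=O)nn2)c(C)c1` is the furthest; in this assay compound 2 gives 24000 nM, and the step of a 7.8-fold higher number from compound 2 to compound 3 (0.89 log units; beyond the scatter) is modest but clear, as is a 4.8-fold lower number from compound 1 to compound 2 (0.68 log units; beyond the scatter). Compound 4 `Cc1cc(C)c(Oc2cc(Nc3ccc(C#N)cc3)ncc2C(=O)NCc2cn(Cc3cccc(C#N)c3)nn2)c(C)c1` differs from compound 3 in one place: cyano in place of chloro on an aromatic carbon, meta to a large group, 3-chlorobenzyl to 3-cyanobenzyl. Among the compounds with values here, the only measured step that bears on a change at this ring carbon is a 1.6-fold higher number from compound 1 to compound 3 (0.21 log units; within the scatter), methyl to chloro, which fell within the scatter. The steps involving compound 2 concern a different part of the molecule, the carbamoyl-for-benzyl exchange on the saturated chain carbon bound to an aromatic nitrogen, and do not speak to a swap on the benzyl ring. Within the data shown here, no measured pair shows cyano against chloro. The expectation is therefore a step of a 1.2-fold lower number from compound 3 to compound 4 (0.10 log units; within the scatter) that does not go beyond the scatter in either direction. Compound 4 is estimated at 150000 nM, with a range from 60000 nM to 350000 nM.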

Compound 4, half-maximal cytotoxic concentration: >= 129000 nM
Compound 4 gave a limit, no number; the forecaster's own chance of this, stated with the estimate: 15%; the middle value is on the limit's open side.
By their numbers in this assay, from the lowest: compound 2; then compounds 1 and 3 (each within the scatter of the next).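

In this assay compound 4 gives >= 129000 nM, which is a limit of the assay and not a number. Going by these compounds alone, the chloro-to-cyano exchange on this aromatic carbon therefore cannot be read against compound 3, and what compound 4 adds is a floor, with the steps to the other two compounds as the only readable information: there is an at least 5.3-fold higher number from compound 2 to compound 4 (0.73 log units; beyond the scatter), so a third substituent on the benzyl ring now stands clear of the carbamoyl compound, as the methyl of compound 1 and the chloro of compound 3 already did, while an at least 1.1-fold higher number from compound 1 to compound 4 (0.05 log units; that floor lies within the scatter) shows no change beyond the scatter for cyano in place of methyl. Across methyl, chloro and cyano at this ring carbon, no compound shown goes against that separation from compound 2, although the limit hides how far compound 4 actually lies from it.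

On these data alone, the true size of the cyano step remains open, and so does whether the tolerance seen with these three substituents extends to an amine or a carboxylic acid on the same ring carbon. As far as these compounds go, it is equally open whether a longer chain in place of the benzyl link would keep the number with compounds 1 and 3 or bring it toward compound 2.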